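The source may hold more compounds than are shown below. What is called first, only, known or untested is meant among the compounds shown, and "the series" means these compounds.

Measured so far, in an assay on isolated protein for inhibition of Gonadotropin-releasing hormone receptor (Rattus norvegicus); on this read-out lower numbers stand for stronger inhibition and higher numbers for weaker inhibition: compound 1 `Cc1cc(C)cc(-c2c(O)nc3cc(Cl)c([N+](=O)[O-])cc3c2OCCC2NCCc3ccccc32)c1` gives 750 nM; compound 2 `Cc1cc(C)cc(-c2c(O)nc3cc(Cl)c([N+](=O)[O-])cc3c2OCCC2NCCCC2C)c1` gives 45 nM.

Compound 1 has the highest number of the two, and its nearest neighbour is compound 2, reached by a 17-fold lower number from compound 1 to compound 2 (1.22 log units; beyond the scatter). Compound 3 `CC[C@H]1CCC[C@@H](CCOc2c(-c3cc(C)cc(C)c3)c(O)nc3cc(Cl)c([N+](=O)[O-])cc23)N1` differs from compound 1 by 6-ethylpiperidin-2-yl in place of 1,2,3,4-tetrahydroisoquinolin-1-yl on a saturated chain carbon, two bonds along the chain from an oxygen on an aromatic ring. For the measured compounds named here, the one measured step that bears on this change, swapping the same bicyclic group for a substituted piperidinyl, was a 17-fold lower number from compound 1 to compound 2 (1.22 log units; beyond the scatter), a large drop. A comparable step is therefore expected for compound 3 in this assay, namely a 17-fold lower number from compound 1 to compound 3 (1.22 log units; beyond the scatter). Compound 3 is estimated at 45 nM, with a range from 10 nM to 200 nM.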

Compound 3, half-maximal inhibitory concentration: 18 nM
Compound 3: the middle estimate sits 2.5-fold (0.40 log units) above what was measured, and the stated range covers the measured number.
By their numbers in this assay, from the lowest: compound 3; then compound 2; then compound 1.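

In this assay, 6-ethylpiperidin-2-yl in place of 1,2,3,4-tetrahydroisoquinolin-1-yl brings a 42-fold lower number from compound 1 to compound 3 (1.62 log units; beyond the scatter) and so goes further than the earlier swap. The choice of piperidinyl group also matters at this place on the chain, with a 2.5-fold lower number from compound 2 to compound 3 (0.40 log units; beyond the scatter) as a modest step beyond the scatter. Nothing available here explains either step. Still open, from the compounds shown here alone, is how unsubstituted piperidin-2-yl or 6-propylpiperidin-2-yl would compare at this position, and how the other stereoisomers of the 6-ethylpiperidin-2-yl group would read.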